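This account rests on a few compounds, and the source may have more. Where it says the series, first, only, none or still open, it means among the compounds named here.

Measured so far in the series:

compound 1 `CCC(=O)N1N=C(c2ccc(C)cc2)CC1c1cn(-c2ccccc2)nc1-c1ccc(Cl)c(Cl)c1`: 29.8%
compound 2 `Fc1ccc(C2=NNC(c3cn(-c4ccccc4)nc3-c3ccc(Cl)c(Cl)c3)C2)cc1`: 45.7%
compound 3 `O=[N+]([O-])c1ccc(N2N=C(c3ccc(Cl)cc3)CC2c2cn(-c3ccccc3)nc2-c2ccc(Cl)c(Cl)c2)cc1`: 48.9%

All three numbers come from a functional assay on the whole organism (strain Wistar) for inhibition, with Rattus norvegicus as the target, read by paw edema, with a stated time of 30 min, at a dose of 50 mg/kg by the oral route; on this read-out higher numbers stand for more inhibition at the one dose given (going by the name of the read-out) and lower numbers for less inhibition. On that read-out compound 1 gives 29.8%, the lowest of the three. Compound 2 gives 45.7%, higher than compound 1 by a margin beyond the usual scatter, and compound 3 gives 48.9%, also higher than compound 1 beyond the scatter. Compound 2 and compound 3 lie within the scatter of each other, so no order between them is claimed. Among the compounds with values here, no pair of the measured compounds differs in only one place, so no single-point step can be read from the measurements themselves.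

Compound 4, `Cc1ccc(C2=NN(C=O)C(c3cn(-c4ccccc4)nc3-c3ccc(Cl)c(Cl)c3)C2)cc1`, is still to be measured. It differs from compound 1 by hydrogen in place of ethyl on a carbonyl carbon; cut one bond further out, the change reads propanoyl to formyl, at the carbonyl carbon whose other neighbour is the amide-type nitrogen in a ring. Within the data shown here, nothing among the measured compounds shows what such a change does here, and it removes only the ethyl, so no step beyond the scatter is expected in this assay in either direction. Compound 4 is estimated at 33%, with a range from 18% to 48%. The step of a number 3.2 percentage points higher from compound 1 to compound 4 (within the scatter) is expected to stay within the scatter.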

Compound 4, a percentage reported as inhibition, in the whole organism at one dose (the size of the read-out at that dose, not a potency): 35.1%
Estimate against measurement, compound 4: 2.1 percentage points below; measured number inside the range.
By their numbers in this assay, from the lowest: compounds 1 and 4 (each within the scatter of the next); then compounds 2 and 3 (each within the scatter of the next).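

Within the data shown here, with hydrogen in place of ethyl on the carbonyl carbon, the first single-place step reads a number 5.3 percentage points higher from compound 1 to compound 4 (within the scatter) in this assay. At this position, then, the change from propanoyl to formyl leaves the read-out within the scatter at the one dose given, so the ethyl is not needed to keep the inhibition seen with compound 1 in this assay, though this rests on a single pair. No measurement at hand bears on why the two acyl groups read alike.

As far as these compounds go, only these two groups have been compared on this carbonyl carbon, so it remains open whether a longer chain such as butanoyl, a phenyl ring or an amine in the place of the ethyl would also stay within the scatter or would move the number beyond it. From the compounds shown here alone, a single-dose percentage also gives no potency, so any difference between propanoyl and formyl at other doses or other times remains open, as does the effect of removing the whole acyl group with the rest of compound 1 unchanged.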